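The compounds below may be only part of what the source reports. "The series", "measured", "known", "first", "only" and "open" are said of these compounds alone.

Compound 1 `CC(C)CSc1nc(N)nc2c1ncn2/C=C1/CC1(CO)CO` is examined in an ADME assay on Akata cells (Homo sapiens) for cytotoxicity, with a stated time of 7 days; a lower number here means that less compound is tolerated, a higher number that more compound is tolerated. In this assay compound 1 gives only a limit, > 20000 nM. Compound 2 `CCCCCCSc1nc(N)nc2c1ncn2/C=C1/CC1(CO)CO` in this assay likewise returns a limit, > 20000 nM. Compound 3 `CCCCCOc1nc(N)nc2c1ncn2/C=C1/CC1(CO)CO` in this assay also returns a limit, > 20000 nM. The steps a step that the two limits leave unreadable from compound 1 to compound 2, a step that the two limits leave unreadable from compound 1 to compound 3 and a step that the two limits leave unreadable from compound 2 to compound 3 thus cannot be sized because of the limit of > 20000 nM in this assay, at which 3 of the 3 values shown sit. Compound 4 `CCCOc1nc(N)nc2c1ncn2/C=C1/CC1(CO)CO` differs from compound 1 by propoxy in place of isobutylsulfanyl on an aromatic carbon. The two measured steps that also end in pentyloxy bear on this exchange, but neither could be read. Compound 4 is therefore expected to show a step that the limit leaves unreadable from compound 1 to compound 4, nothing readable beyond the scatter. For compound 4 the estimate in this assay is 25000 nM, between 10000 nM and 60000 nM, most probably again only a limit.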

Compound 4, half-maximal cytotoxic concentration: > 20000 nM
Compound 4 was reported as a limit; the forecaster's own chance of this, stated with the estimate: 85%; the middle value does not contradict the limit.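

The steps joining compound 4 to compound 1, compound 2 and compound 3 cannot be read in this assay, because all four compounds rest on one limit: the limit of > 20000 nM in this assay, at which 4 of the 4 values shown sit. The compounds shown leave open whether these side chains differ in half-maximal cytotoxic concentration at all.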